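Phenyl for tert-butyl on the pyrazole carbon: an expectation

This account rests on a few compounds, and the source may have more. Where it says the series, first, only, none or still open, it means among the compounds named here.

Compound 2 `Cn1nc(C(C)(C)C)cc1NC(=O)Nc1cc(C(F)(F)F)cc(C(F)(F)F)c1` gives 0.4 degrees C in an assay on isolated protein for inhibition of Ephrin type-A receptor 2 (Homo sapiens), read by thermal shift assay, tested at 10 uM; a higher number here means that the compound stabilises the target more against heat, a lower number that the compound stabilises the target less. Its two measured neighbours lie within the usual scatter of it: compound 1 `CC(C)(C)c1cc(NC(=O)Nc2cc(C(F)(F)F)cc(C(F)(F)F)c2)n(-c2ccccc2)n1` gives 0.8 degrees C, and compound 3 `CC(C)(C)c1cc(NC(=O)Nc2cc(C(F)(F)F)cc(C(F)(F)F)c2)n(-c2ccc(Br)cc2)n1` gives 0.3 degrees C, so none of the three can be called the stronger stabiliser. The steps among them, a number 0.40 degrees C lower from compound 1 to compound 2 (within the scatter), a number 0.50 degrees C lower from compound 1 to compound 3 (within the scatter) and a number 0.10 degrees C lower from compound 2 to compound 3 (within the scatter), all change the group on the aromatic nitrogen or add a bromo, and all stay within the scatter.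

Compound 4 `Cn1nc(-c2ccccc2)cc1NC(=O)Nc1cc(C(F)(F)F)cc(C(F)(F)F)c1` differs from compound 2 in another place: phenyl in place of tert-butyl on an aromatic carbon. For the measured compounds named here, no measured step touches this carbon, so nothing directly supports a shift in either direction; the only guidance is that every change tried so far on this core left this assay unchanged beyond the scatter. Compound 4 is therefore expected to show no change at the digits printed from compound 2 to compound 4 (within the scatter), a step of no consequence. The estimate for compound 4 is 0.4 degrees C, with a range from -0.6 degrees C to 1.4 degrees C.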

Compound 4, shift of the target's melting temperature: 0.9 degrees C
Estimate against measurement, compound 4: 0.50 degrees C below; the range from low to high includes it.
By their numbers in this assay, from the lowest: compounds 3, 2, 1 and 4 (each within the scatter of the next).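

For the compounds shown here, this is the first change on this aromatic carbon of the shared core, and in this assay phenyl in place of tert-butyl gives a number 0.50 degrees C higher from compound 2 to compound 4 (within the scatter). A six-membered aromatic ring of carbon only can therefore stand here in place of a group with no ring, with no step beyond the scatter. This carbon thus joins the aromatic nitrogen as a place where the compounds shown reveal no difference that can be read. Nothing available bears on why this step is so small.

Still open, as far as these compounds go, is whether any other group on this carbon, such as an amine, a carboxylic acid or a longer chain, would give a step beyond the scatter. Also open, from the compounds shown here alone, is whether any change to the shared core can do so.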